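A few compounds are considered here, and "the series" means these few. Any claim that something is new, unique, unknown or untested is made for them only; others in the source may bear on it.

Three analogues on a shared core have been measured in a functional assay on NCI/ADR-RES cells (Homo sapiens) for antiproliferative activity, with a stated time of 48 h; a higher number here means a weaker inhibitor of growth, a lower number a stronger inhibitor of growth. Compound 1 `Cc1cc(O)c(C2=NN(c3ccc(S(N)(=O)=O)cc3)C(c3ccccc3Cl)C2)cc1Cl` gives 2700 nM, compound 2 `Cc1cc(O)c(C2=NN(c3ccc(S(N)(=O)=O)cc3)C(/C=C/c3ccccc3)C2)cc1Cl` gives 9260 nM, and compound 3 `COc1ccc(C2CC(c3cc(Cl)c(C)cc3O)=NN2c2ccc(S(N)(=O)=O)cc2)cc1OC` gives 3390 nM. Compound 3 sits close to compound 1, with a 1.3-fold higher number from compound 1 to compound 3 (0.10 log units; within the scatter), and apart from compound 2, with a 2.7-fold lower number from compound 2 to compound 3 (0.44 log units; beyond the scatter). Compound 4 `COc1ccc(C2CC(c3cc(Cl)c(C)cc3O)=NN2c2ccc(S(N)(=O)=O)cc2)c(OC)c1OC` differs from compound 3 by methoxy in place of hydrogen on an aromatic carbon. Within the data shown here, no measured step adds or removes a single substituent on the aryl group at the saturated ring carbon; the steps swap that whole group, as in a 3.4-fold higher number from compound 1 to compound 2 (0.54 log units; beyond the scatter), so none bears directly on this change. The expected step in this assay is therefore a 1.0-fold higher number from compound 3 to compound 4 (0.00 log units; within the scatter), nothing beyond the scatter. For compound 4 the estimate in this assay is 3400 nM, within 1500 nM to 8000 nM.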

Compound 4, concentration for 50% growth inhibition: 2580 nM
Estimate against measurement, compound 4: 1.3-fold (0.12 log units) above, and the stated range covers the measured number.
By their numbers in this assay, from the lowest: compounds 4, 1 and 3 (each within the scatter of the next); then compound 2.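

In this assay, methoxy in place of hydrogen on the aromatic carbon ortho to a large group leaves the number within the scatter, a 1.3-fold lower number from compound 3 to compound 4 (0.12 log units; within the scatter), and this is the only step shown that adds a single substituent to this aryl group. The 2,3,4-trimethoxyphenyl group also stays within the scatter of 2-chlorophenyl, a 1.0-fold lower number from compound 1 to compound 4 (0.02 log units; within the scatter), while the step from 2-phenylethenyl lies beyond it, a 3.6-fold lower number from compound 2 to compound 4 (0.55 log units; beyond the scatter). No evidence available here bears on these steps.

On these data alone, whether an amine or a carboxylic acid on this aryl group would move the number beyond the scatter remains open.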